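The source may report more compounds than this note shows. Statements on the series, on what has been measured and on what is new or still open speak of the compounds shown alone.

Three compounds share one core and differ only in the aryl amide at its end. Compound 1 `O=C(/C=C/c1cccc(NC(=O)c2ccccc2Br)c1)c1nc2ccccc2[nH]1` gives 4520 nM in a functional assay on MCF7 cells (Homo sapiens) for antiproliferative activity, read by MTT assay, with a stated time of 48 h; a lower number here means a stronger inhibitor, a higher number a weaker inhibitor. Compound 2 `Cc1ccccc1C(=O)Nc1cccc(/C=C/C(=O)c2nc3ccccc3[nH]2)c1` gives 5870 nM in this assay, and compound 3 `Cc1cccc(C(=O)Nc2cccc(/C=C/C(=O)c3nc4ccccc4[nH]3)c2)c1` gives 5590 nM in this assay. Compound 3 thus stands second highest of the three numbers, but there is only a 1.1-fold lower number from compound 2 to compound 3 (0.02 log units; within the scatter) and a 1.2-fold higher number from compound 1 to compound 3 (0.09 log units; within the scatter), so the three numbers are not separated.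

Compound 4 `O=C(Nc1cccc(/C=C/C(=O)c2nc3ccccc3[nH]2)c1)c1cccc(C(F)(F)F)c1` is not yet measured. It differs from compound 3 by trifluoromethyl in place of methyl on an aromatic carbon. Among the compounds with values here, the only measured step that swaps one small group on an aromatic carbon is a 1.3-fold higher number from compound 1 to compound 2 (0.11 log units; within the scatter), and no measured step involves a trifluoromethyl at all. Each measured step stays inside the scatter, so the step from compound 3 to compound 4 is expected to be a 1.0-fold lower number from compound 3 to compound 4 (0.01 log units; within the scatter), with no direction beyond the scatter. Compound 4 is therefore estimated at 5500 nM in this assay, with a range from 2500 nM to 12000 nM.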

Compound 4, half-maximal inhibitory concentration: 21500 nM
Compound 4: the middle estimate sits 3.9-fold (0.59 log units) below what was measured; measured number above the stated range.
By their numbers in this assay, from the lowest: compounds 1, 3 and 2 (each within the scatter of the next); then compound 4.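

In this assay, within the data shown here, the change from 3-methylphenyl to 3-(trifluoromethyl)phenyl is the first swap at the end of the core to separate two compounds, with (a 3.8-fold higher number from compound 3 to compound 4 (0.59 log units; beyond the scatter)). The other two steps agree, with (a 3.7-fold higher number from compound 2 to compound 4 (0.56 log units; beyond the scatter)) and (a 4.8-fold higher number from compound 1 to compound 4 (0.68 log units; beyond the scatter)), so compound 4 is the weakest of the four, while the two methyl compounds and the bromo compound of the earlier set remain unseparated. Nothing available explains this loss.

Going by these compounds, whether a chlorine, a methoxy group or an amine on the same carbon would stay with compound 3 or fall with compound 4 remains open. Also open, on these data alone, is whether trifluoromethyl would give a step of this size on another carbon of that ring.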